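This account rests on a few compounds, and the source may have more. Where it says the series, first, only, none or still open, it means among the compounds named here.

Measured so far:
compound 1 `Cc1ccc(Cc2ncn3c(O)ncnc23)cc1`; compound 2 `Cc1ccc(Cc2ncn3c(S)ncnc23)cc1`; compound 3 `CSc1ncnc2c(Cc3ccc(C)cc3)ncn12`.

In a functional assay on CCRF-CEM cells (Homo sapiens) for cytotoxicity (a higher number here means that more compound is tolerated, a lower number that less compound is tolerated), compound 1 gives > 833000 nM, a limit of the assay. Compound 2 gives 32800 nM and compound 3 gives 389000 nM. Compound 3 thus holds the highest of the two numbers; its nearest neighbour is compound 2, with a 12-fold higher number from compound 2 to compound 3 (1.07 log units; beyond the scatter). Compound 4 `Cc1ccc(CSc2ncnc3c(Cc4ccc(C)cc4)ncn23)cc1` differs from compound 3 by 4-methylphenyl in place of hydrogen on a saturated chain carbon bound to a sulfur. Among the measured compounds shown here, no measured step makes this exact change. The closest precedent is the earlier methylation step, a 12-fold higher number from compound 2 to compound 3 (1.07 log units; beyond the scatter), a large rise; the other shown step is an at least 2.1-fold lower number from compound 1 to compound 3 (0.33 log units; beyond the scatter). Compound 4 is expected to show a step of a 1.1-fold lower number from compound 3 to compound 4 (0.05 log units; within the scatter), not clearly beyond the scatter. Compound 4 is estimated at 350000 nM, range 80000 nM to 1000000 nM.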

Compound 4, half-maximal cytotoxic concentration: > 111000 nM
Compound 4: no number, only a limit (the forecaster's own chance of this, stated with the estimate: 30%); the middle value does not contradict the limit.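

In this assay compound 4 gives > 111000 nM, which is a limit. Replacing hydrogen on the sulfur with 4-methylbenzyl gives an at least 3.3-fold higher number from compound 2 to compound 4 (0.52 log units; beyond the scatter), so the rise seen with methyl on the sulfur is also seen with a group carrying an aromatic ring. The step from compound 3 to compound 4 cannot be read, so methyl and 4-methylbenzyl cannot be ranked on this position. Still open, on these data alone, is how a longer chain without a ring, or an amine or carboxylic acid on that chain, would behave on the sulfur.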